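The compounds below may be only part of what the source reports. "The series", "measured", "known", "first", "only" and "open" are said of these compounds alone.

Compound 1, `Cc1ccc2oc(SCC(=O)Nc3ccc(-c4nc(-c5ccccc5)c(-c5ccccc5)n4C)cc3)nc2c1`: 25.6%
Compound 2, `Cn1nnnc1SCC(=O)Nc1ccc(-c2nc(-c3ccccc3)c(-c3ccccc3)n2C)cc1`: 60.6%

Within the data shown here, in a functional assay on HT-29 cells (Homo sapiens) for cytotoxicity, read by MTT assay, with a stated time of 24 h, tested at 6.4 ug/mL (a lower number here means a weaker effect, a higher number a stronger effect of the compound at the concentration tested), compound 2 stands highest of the two numbers measured so far; its nearest neighbour is compound 1, and the step of a number 35 percentage points higher from compound 1 to compound 2 (beyond the scatter) separates them. Compound 3, `Cn1ccnc1SCC(=O)Nc1ccc(-c2nc(-c3ccccc3)c(-c3ccccc3)n2C)cc1`, is not yet measured. It differs from compound 2 in one place: 1-methyl-1H-imidazol-2-yl in place of 1-methyl-1H-tetrazol-5-yl on a sulfur. Among the measured compounds shown here, the only measured step that bears on the same position is the one from compound 1 to compound 2, where the 5-methyl-1,3-benzoxazol-2-yl on the sulfur gave way to 1-methyl-1H-tetrazol-5-yl and the read-out rose by a large amount. For the measured compounds named here, no measured pair shows what 1-methyl-1H-imidazol-2-yl does there, so the direction of a number 12.6 percentage points lower from compound 2 to compound 3 (beyond the scatter) is expected to be uncertain, with a downward step or none beyond the scatter both plausible. Compound 3 is therefore estimated at 48%, within a range from 25% to 70%.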

Compound 3, a percentage reported as activity, at one concentration (the size of the read-out at that concentration, not a potency): 30.7%
For compound 3 the middle estimate is 17.3 percentage points above the measured one, within the range that was stated.
By their numbers in this assay, from the lowest: compounds 1 and 3 (each within the scatter of the next); then compound 2.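

In this assay, 1-methyl-1H-imidazol-2-yl on the sulfur gives a number 29.9 percentage points lower from compound 2 to compound 3 (beyond the scatter), so among the compounds shown, a five-membered aromatic ring of 6 heavy atoms is not enough to keep the higher read-out: the two groups have the same heavy-atom count but differ in their share of carbon and nitrogen. The second comparison, a number 5.1 percentage points higher from compound 1 to compound 3 (within the scatter), puts the smaller imidazole group level with the 5-methyl-1,3-benzoxazol-2-yl group, leaving 1-methyl-1H-tetrazol-5-yl alone at the higher read-out. Nothing available explains this difference.

The compounds shown leave open whether a ring with three nitrogen atoms, such as a 1,2,4-triazole, would fall with compound 2 or with compound 3. They also leave open what a tetrazole without the methyl group, or a carboxylic acid on the sulfur-bearing chain, would give.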